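Bromo at the pyrazole carbon of compound 1

The source may hold more compounds than are shown below. What is called first, only, known or untested is meant among the compounds shown, and "the series" means these compounds.

Measured so far:
compound 1 `Cc1ccc(Cl)cc1N1CCN(c2ncnc3[nH]ncc23)CC1`: 13 nM
compound 2 `Cc1nc(N2CCN(c3cc(Cl)ccc3C)CC2)c2cn[nH]c2n1`: > 2000 nM

Going by the values given here, in an assay for inhibition of ribosomal protein S6 kinase beta-1 variant D18H,T412E (Homo sapiens), read by a luciferase reporter and chemiluminescence, with a stated time of 3 h (a higher number here means a weaker inhibitor, a lower number a stronger inhibitor), compound 1 gives 13 nM, the only plain number in the set. Compound 2 sits at a limit of the assay, > 2000 nM (the limit of > 2000 nM in this assay, at which 1 of the 2 values shown sits). Among the compounds with values here, the one measured step, an at least 150-fold higher number from compound 1 to compound 2 (2.18 log units; beyond the scatter), is a methyl on the core and not at the position now changed. Compound 3 `Cc1ccc(Cl)cc1N1CCN(c2ncnc3[nH]nc(Br)c23)CC1` differs from compound 1 by bromo in place of hydrogen on an aromatic carbon. Within the data shown here, no measured step touches this position, so the large step to compound 2 gives no direct guide. A change within or just beyond the scatter is expected, a 1.9-fold higher number from compound 1 to compound 3 (0.28 log units; within the scatter). Compound 3 is estimated at 25 nM, between 4 nM and 200 nM.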

Compound 3, half-maximal inhibitory concentration: 7 nM
Compound 3: middle estimate off by 3.6-fold (0.55 log units), on the high side, within the range that was stated.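

Bromo in place of hydrogen on this aromatic carbon of the five-membered ring gives a 1.9-fold lower number from compound 1 to compound 3 (0.27 log units; within the scatter), so the step cannot be told from no change. Going by these compounds alone, this carbon therefore accepts a bromine, and the earlier compounds showed nothing about substitution here. Nothing in the data gives a cause for this step.

Bromo is the only replacement for hydrogen shown at this carbon, so the response to an amine, a carboxylic acid or a longer alkyl chain here remains open. As far as these compounds go, whether bromo would have the same outcome on other parts of the series also remains open.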